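The source may report more compounds than this note shows. Statements on the series, on what has been measured and on what is new or still open speak of the compounds shown alone.

In an assay on HeLa cells for displacement of a labelled ligand from adenosine receptor A3 (Homo sapiens), with a stated time of 180 min, tested at 1 uM (a higher number here means more inhibition at the concentration tested (going by the name of the read-out), a lower number less inhibition), compound 1 `CC1=C(C(=O)OC(C)C)C(C2CCCC2)N/C(=N/C#N)N1` gives 3%. Compound 2 `CC1=C(C(=O)OC(C)C)C(c2ccccc2)N/C(=N/C#N)N1` differs from compound 1 in a single place: phenyl in place of cyclopentyl on a saturated ring carbon

In this assay compound 2 gives 6%; the step is a number 3 percentage points higher from compound 1 to compound 2 (within the scatter). Compound 3 `CC1=C(C(=O)OC(C)C)C(C2CCCC2)NC(=O)N1` carries a different core from compound 1, and the difference between the two cores is not broken down here. In this assay compound 3 gives 7%. Compound 4 `CC1=C(C(=O)OC(C)C)C(c2ccccc2)NC(=O)N1` has not yet been measured; it differs from compound 3 by the same change: phenyl in place of cyclopentyl on a saturated ring carbon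

Because the earlier step was a number 3 percentage points higher from compound 1 to compound 2 (within the scatter), a step of similar size is expected here, namely a number 2 percentage points higher from compound 3 to compound 4 (within the scatter). For compound 4 the expected read-out in this assay is 9%, estimated to lie between 0% and 20%.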

Compound 4, a percentage reported as inhibition, at one concentration (the size of the read-out at that concentration, not a potency): 2%
Beside the measured number, compound 4's estimate is 7 percentage points above it; the measured number falls inside the stated range.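

In this assay, with phenyl in place of cyclopentyl on a saturated ring carbon, the new step is a number 5 percentage points lower from compound 3 to compound 4 (within the scatter). Set beside the same change on the other core, this step does not differ from the earlier one: the same change on two cores in this assay, a number 3 percentage points higher (within the scatter) from compound 1 to compound 2 and a number 5 percentage points lower (within the scatter) from compound 3 to compound 4, 8 percentage points apart, within the scatter of two such steps. This shows no sign that the outcome of the change depends on the core, but every step here lies within the scatter, so it does not show that the change carries over in any measurable way.

The compounds shown leave open how a longer alkyl chain or an amine-bearing group on that saturated ring carbon would read. They also leave open what a carboxylic acid would do in place of the isopropoxycarbonyl group.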